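A few compounds are considered here, and "the series" means these few. Any claim that something is new, unique, unknown or untested is made for them only; others in the source may bear on it.

Working notes on the series, all tested in a functional assay on A-431 cells (Homo sapiens) for cytotoxicity, read by MTT assay, with a stated time of 48 h; a higher number here means a weaker inhibitor, a lower number a stronger inhibitor. Compound 1 `CCCCCCCCCCCCCCNC(=O)[C@@H](N)[C@@H](C)O` gives 14600 nM. Compound 2 `CCCCCCCCNC(=O)[C@@H](NC(=O)c1cc2ccccc2o1)[C@@H](C)O` gives 52700 nM, and compound 3 `CCCCCCCCCCCCNC(=O)[C@@H](NC(=O)c1cc2ccccc2o1)[C@@H](C)O` gives 20000 nM. Compound 3 thus stands second highest of the three numbers: compound 1 lies within the scatter of it, compound 2 beyond it. Going by the values given here, the only single-place step measured, a 2.6-fold lower number from compound 2 to compound 3 (0.42 log units; beyond the scatter), concerns the chain on the amide-type nitrogen, not the acyl group.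

Compound 4 `C/C=C/C=C/C(=O)N[C@H](C(=O)NCCCCCCCCCCCC)[C@@H](C)O` differs from compound 3 by penta-1,3-dien-1-yl in place of 1-benzofuran-2-yl on a carbonyl carbon. Among the compounds with values here, no measured step touches an exchange of this kind, so nothing in the numbers points to a direction. The step of no change at the digits printed from compound 3 to compound 4 (within the scatter) is therefore expected to fall within the scatter. The estimate for compound 4 is 20000 nM, with a range from 7000 nM to 60000 nM.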

Compound 4, half-maximal inhibitory concentration: 171000 nM
Estimate against measurement, compound 4: 8.6-fold (0.93 log units) below, outside the stated range (above it).
By their numbers in this assay, from the lowest: compounds 1 and 3 (each within the scatter of the next); then compound 2; then compound 4.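

On this carbonyl carbon, penta-1,3-dien-1-yl is not interchangeable with 1-benzofuran-2-yl in this assay: the exchange gives an 8.6-fold higher number from compound 3 to compound 4 (0.93 log units; beyond the scatter). Going by these compounds alone, the acyl group therefore moves the number too, whereas the earlier compounds gave a measured step only on the chain on the amide-type nitrogen. Nothing at hand explains this step.

Still open, from the compounds shown here alone, is whether the step follows the loss of the two rings or the entry of the two double bonds, which a phenyl or a saturated pentyl group at this carbonyl carbon could separate. Also open, going by these compounds, is whether it holds with the shorter chain of compound 2.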